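Ester replacing the bulky ether: expectation for compound 4

A few compounds are considered here, and "the series" means these few. Any claim that something is new, unique, unknown or untested is made for them only; others in the source may bear on it.

Compound 1 `C=C1CC[C@@H]2[C@](C)(COC(C)=O)[C@H](OC(C)=O)CC[C@@]2(C)[C@@H]1C/C=C1/C(=O)OC[C@H]1OC(C)=O` carries acetyl on an oxygen on a saturated carbon whose other neighbour is a saturated chain carbon; in a functional assay on MCF7 cells (Homo sapiens) for cytotoxicity, read by sulforhodamine B assay (on this read-out higher numbers stand for an effect only at larger amounts of compound and lower numbers for an effect already at smaller amounts), compound 1 gives 10 uM. Compound 2 `C=C1CC[C@@H]2[C@](C)(CO[Si](C(C)C)(C(C)C)C(C)C)[C@H](OC(C)=O)CC[C@@]2(C)[C@@H]1C/C=C1/C(=O)OC[C@H]1OC(C)=O` bears at that oxygen a group of 10 heavy atoms instead, and in this assay compound 2 gives 14 uM. The change from compound 2 to compound 1 is a group of 3 heavy atoms (2 carbon, 1 oxygen; no ring) in place of a group of 10 heavy atoms (9 carbon, 1 silicon; no ring), on an oxygen on a saturated carbon and it made a step of a 1.4-fold lower number from compound 2 to compound 1 (0.15 log units; within the scatter).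

Compound 3 `C=C1CC[C@@H]2[C@](C)(CO[Si](C(C)C)(C(C)C)C(C)C)[C@H](O)CC[C@@]2(C)[C@@H]1C/C=C1/C(=O)OC[C@H]1O` keeps the group of 10 heavy atoms but differs from compound 2 in more than one place; the difference between the two cores is not broken down here. In this assay compound 3 gives 2.88 uM, the lowest of the three numbers and beyond the scatter from compound 1 and from compound 2.

Compound 4 `C=C1CC[C@@H]2[C@](C)(COC(C)=O)[C@H](O)CC[C@@]2(C)[C@@H]1C/C=C1/C(=O)OC[C@H]1O` is not yet measured. It differs from compound 3 by a group of 3 heavy atoms (2 carbon, 1 oxygen; no ring) in place of a group of 10 heavy atoms (9 carbon, 1 silicon; no ring), on an oxygen on a saturated carbon, the same change as from compound 2 to compound 1, with the place described in identical words. Because that earlier step was a 1.4-fold lower number from compound 2 to compound 1 (0.15 log units; within the scatter), little movement is expected. Near the value of compound 3, compound 4 is expected at 2.2 uM, with a range from 0.9 uM to 6 uM. The expected step is estimated as a 1.3-fold lower number from compound 3 to compound 4 (0.12 log units; within the scatter).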

Compound 4, concentration for half-maximal effect: 18.3 uM
The estimate for compound 4 lay 8.3-fold (0.92 log units) below the measured number; measured number above the stated range.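

In this assay, acetyl in place of the group of 10 heavy atoms, on an oxygen on a saturated carbon, gives a 6.4-fold higher number from compound 3 to compound 4 (0.80 log units; beyond the scatter). The change therefore does not carry over unchanged between these two cores, and its outcome in this series depends on the core that bears it: the same change on two cores in this assay, a 1.4-fold lower number (0.15 log units; within the scatter) from compound 2 to compound 1 and a 6.4-fold higher number (0.80 log units; beyond the scatter) from compound 3 to compound 4, 8.9-fold (0.95 log units) apart, beyond the scatter of two such steps. Going by these compounds alone, this rests on only two pairs, and the cores differ in more than one place, so the data do not show which core difference goes with the gap, nor what underlies the response on either core.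

Open, on these data alone, is how each core responds to other groups on that oxygen, such as a free hydroxyl, a methyl ether or a longer acyl chain. Also open, as far as these compounds go, is whether an amine or a carboxylic acid at that place would follow the pattern of either core.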